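This account rests on a few compounds, and the source may have more. Where it says the series, first, only, none or still open, it means among the compounds named here.

Working notes on the thiourea series built on the shared core of compound 1, `S=C(NCc1ccccc1)Nc1ccc2ncnc(Nc3ccccc3Br)c2c1`. In a functional assay on MDA-MB-231 cells (Homo sapiens) for inhibition, read by MTT assay, with a stated time of 48 h (on this read-out higher numbers stand for weaker inhibition of growth and lower numbers for stronger inhibition of growth), compound 1 gives only a limit, > 30000 nM. Compound 2, `S=C(Nc1ccc(Cl)cc1)Nc1ccc2ncnc(Nc3cccc(Br)c3)c2c1`, carries a 4-chlorophenyl on the amide-type nitrogen and in this assay gives 8200 nM; that is the higher of the two numbers in hand. Compound 3, `FC(F)(F)c1cc(NC(=S)Nc2ccc3ncnc(Nc4cccc(Br)c4)c3c2)cc(C(F)(F)F)c1`, in this assay gives 800 nM, and the gap between compound 2 and compound 3 lies beyond the scatter. Among the compounds with values here, no measured pair differs in one place, so no step between measured compounds can be read on the shared core.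

Compound 4, `S=C(NCc1ccc(Cl)cc1)Nc1ccc2ncnc(Nc3cccc(Br)c3)c2c1`, is compound 2 with 4-chlorobenzyl in place of 4-chlorophenyl on an amide-type nitrogen. Within the data shown here, compound 1, the one other member with a benzyl-type group on the amide-type nitrogen, in this assay gives only a limit, > 30000 nM, though compound 1 differs from compound 2 in more than that one place, so this is not a single step. The expectation for compound 4 is nonetheless weaker inhibition than compound 2, with a step of a 2.4-fold higher number from compound 2 to compound 4 (0.39 log units; beyond the scatter) in this assay. Compound 4 is estimated at 20000 nM, within 6000 nM to 60000 nM in this assay.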

Compound 4, concentration for 50% growth inhibition: 23000 nM
For compound 4 the middle estimate is 1.2-fold (0.06 log units) below the measured one, within the range that was stated.
By their numbers in this assay, from the lowest: compound 3; then compound 2; then compound 4. At a limit, above all of these: compound 1.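

In this assay, within the data shown here, 4-chlorobenzyl in place of 4-chlorophenyl on an amide-type nitrogen gives the first step that can be read on the shared core: a 2.8-fold higher number from compound 2 to compound 4 (0.45 log units; beyond the scatter). With the 4-chloro-substituted ring kept and the rest of the structure unchanged, this pair shows that inhibition of growth in the cells responds to this change on the nitrogen whose other neighbour is the thiocarbonyl carbon, and that the 4-chlorophenyl member gives the stronger inhibition. Compound 1 stays outside this step, since it differs from both members in more than one place, and its value is a limit rather than a number: the limit of > 30000 nM in this assay, at which 1 of the 4 values shown sits.

Going by these compounds, whether the same step holds with other groups on the ring remains open, since the other steps cannot be read, and this one pair sets no trend for compound 1 or compound 3. Also open, on these data alone, is how the read-out responds when the chain on this nitrogen is extended further, as with a 2-phenylethyl group, or when the ring carries an amine or a carboxylic acid in place of the chlorine.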